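The source may hold more compounds than are shown below. What is called first, only, known or untested is meant among the compounds shown, and "the series" means these compounds.

Compound 1 `O=C(Nc1ccc(F)c(-c2nc3ncc(-c4ccc(F)c(F)c4)cc3[nH]2)c1)N1CCCC1`: 12000 ng.h/mL
Compound 2 `O=C(Nc1ccc(F)c(-c2nc3ncc(-c4cc(F)ccc4F)cc3[nH]2)c1)N1CCCC1`: 5620 ng.h/mL
Compound 3 `O=C(Nc1ccc(F)c(-c2nc3ncc(-c4cncc(F)c4)cc3[nH]2)c1)N1CCCC1`: 1560 ng.h/mL

All three numbers come from an ADME assay on the whole organism (Mus musculus, strain Swiss Webster) for pharmacokinetics, read by LC-MS, at a dose of 50 mg/kg by the oral route; a higher number here means more compound in the circulation at the dose given, a lower number less compound in the circulation. Compound 3 gives the lowest number of the three, clearly under both of the others. Compound 4 `O=C(Nc1ccc(F)c(-c2nc3ncc(-c4ccc(F)cc4)cc3[nH]2)c1)N1CCCC1` carries 4-fluorophenyl in place of the 5-fluoropyridin-3-yl of compound 3, on an aromatic carbon: 4-fluorophenyl in place of 5-fluoropyridin-3-yl on an aromatic carbon.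

The closest evidence is the two steps that brought in this same 5-fluoropyridin-3-yl in place of a difluorophenyl group: a 7.7-fold lower number from compound 1 to compound 3 (0.89 log units; beyond the scatter) and a 3.6-fold lower number from compound 2 to compound 3 (0.56 log units; beyond the scatter). Both lie beyond the scatter. Compound 4 goes the opposite way, back to a fluorinated phenyl, although its particular group has not been measured. The choice of phenyl group also counts, as a 2.1-fold lower number from compound 1 to compound 2 (0.33 log units; beyond the scatter) shows, so the result could land near either compound 1 or compound 2. A rise of similar size is therefore expected, a 5.1-fold higher number from compound 3 to compound 4 (0.71 log units; beyond the scatter). The estimated value for compound 4 is 8000 ng.h/mL, with an expected range of 3500 ng.h/mL to 18000 ng.h/mL.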

Compound 4, area under the concentration-time curve: 10200 ng.h/mL
Beside the measured number, compound 4's estimate is 1.3-fold (0.11 log units) below it; the measured number falls inside the stated range.
By their numbers in this assay, from the lowest: compound 3; then compounds 2, 4 and 1 (each within the scatter of the next, the first and the last beyond it).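

Fluorine on a phenyl ring at this position gives a high number in this assay even with only one fluorine present, and the low number of compound 3 does not return (a 6.5-fold higher number from compound 3 to compound 4 (0.82 log units; beyond the scatter)). Compound 4 also lies within the scatter of both difluorophenyl compounds (a 1.8-fold higher number from compound 2 to compound 4 (0.26 log units; within the scatter); a 1.2-fold lower number from compound 1 to compound 4 (0.07 log units; within the scatter)). Among these four compounds, then, the 5-fluoropyridin-3-yl group alone stands clearly apart, while 4-fluorophenyl does as well as either difluorophenyl group.

Still open, from the compounds shown here alone, is whether the ring nitrogen or the different fluorine position carries the step from the pyridine to the phenyl, a question 3-fluorophenyl could address, and how a phenyl without fluorine or one bearing a methoxy group would read. No measurement shown here explains why these groups give the numbers they do.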